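The source may report more compounds than this note shows. Statements on the series, on what has been measured and on what is new or still open speak of the compounds shown alone.

Going by the values given here, in a functional assay on K562 cells (Homo sapiens) for antiproliferative activity (a lower number here means a stronger inhibitor of growth, a higher number a weaker inhibitor of growth), compound 2 `CC(C)(C)C(=O)OCC1(CO)C/C(=C\CCCCCCCCCCCO)C(=O)O1` gives 1.09 ug/mL, the higher of the two numbers so far, and compound 1 `COCCCCCCCCCCCCCCC/C=C1\CC(CO)(COC(=O)C(C)(C)C)OC1=O` gives 0.189 ug/mL. Next in the series is compound 3 `CC(=O)OCCCCCCCCCCCCCCC/C=C1\CC(CO)(COC(=O)C(C)(C)C)OC1=O`, with this change from compound 2: 4-acetoxybutyl in place of hydroxy on a saturated chain carbon, ten or more bonds along the chain from a double-bonded chain carbon. Thus 4-acetoxybutyl stands in place of hydroxy on a saturated chain carbon. Among the compounds with values here, one measured step bears on this: a 5.8-fold higher number from compound 1 to compound 2 (0.76 log units; beyond the scatter), where hydroxy replaces 4-methoxybutyl at that place. Within the data shown here, the new change runs the opposite way, but with 4-acetoxybutyl, which no measured compound carries. A step of similar size towards a lower number in this assay is therefore expected, with less certainty. The expected step is a 3.6-fold lower number from compound 2 to compound 3 (0.56 log units; beyond the scatter). For compound 3 the estimated value is 0.3 ug/mL, with an expected range from 0.1 ug/mL to 0.9 ug/mL.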

Compound 3, concentration for 50% growth inhibition: 0.959 ug/mL
Compound 3: the middle estimate sits 3.2-fold (0.50 log units) below what was measured; the whole stated range lies below it.
By their numbers in this assay, from the lowest: compound 1; then compounds 3 and 2 (each within the scatter of the next).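

In this assay, 4-acetoxybutyl in place of hydroxy gives a 1.1-fold lower number from compound 2 to compound 3 (0.06 log units; within the scatter), so the longer chain with an acetyl-capped oxygen does not carry over the step seen between compound 1 and compound 2. At equal chain length, acetyl in place of methyl on an oxygen on a saturated carbon gives a 5.1-fold higher number from compound 1 to compound 3 (0.71 log units; beyond the scatter), so added length alone does not account for the low number of compound 1; among these three compounds, only the methyl-capped chain stands apart. No measurement shown gives a reason for this difference between the methyl and acetyl caps.

Still open, on these data alone, is whether 4-hydroxybutyl at this place would read with compound 1 or with compound 2 and compound 3. As far as these compounds go, it is also open how an amine, a carboxylic acid or an ethyl ether would read on a saturated chain carbon at this place.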